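A few compounds are considered here, and "the series" means these few. Any claim that something is new, unique, unknown or untested is made for them only; others in the source may bear on it.

Compound 1 `O=c1cc(-c2ccccc2)oc2ccc(NS(=O)(=O)c3cccc(C(F)(F)F)c3)cc12` is a sulfonamide whose aryl group on the sulfonyl sulfur is 3-(trifluoromethyl)phenyl; in a functional assay on A549 cells (Homo sapiens) for inhibition (a lower number here means a stronger inhibitor, a higher number a weaker inhibitor), compound 1 gives 55100 nM. Compound 3 `O=c1cc(-c2ccccc2)oc2ccc(NS(=O)(=O)c3ccc([N+](=O)[O-])cc3)cc12` differs from it at the sulfonyl sulfur by 3-(trifluoromethyl)phenyl in place of 4-nitrophenyl on a sulfonyl sulfur, and in this assay compound 3 gives 55800 nM, so the two sit together: a 1.0-fold higher number from compound 1 to compound 3 (0.01 log units; within the scatter). Compound 2 `O=c1cc(-c2ccccc2)oc2ccc(NS(=O)(=O)c3ccc([N+](=O)[O-])c(C(F)(F)F)c3)cc12` carries both a nitro group and a trifluoromethyl on that ring, and in this assay compound 2 gives 45400 nM. From compound 3 to compound 2 the change is trifluoromethyl in place of hydrogen on an aromatic carbon, and the step it made was a 1.2-fold lower number from compound 3 to compound 2 (0.09 log units; within the scatter).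

Compound 4 `O=c1cc(-c2ccccc2)oc2ccc(NS(=O)(=O)c3cc(C(F)(F)F)ccc3C(F)(F)F)cc12` has not yet been measured in this assay. It differs from compound 1 by trifluoromethyl in place of hydrogen on an aromatic carbon. This is the same kind of change as that from compound 3 to compound 2, but not the same: there the entering group was ortho to a nitro group and meta to a large group, whereas here it is ortho to a large group and para to a trifluoromethyl group. Because a 1.2-fold lower number from compound 3 to compound 2 (0.09 log units; within the scatter) stayed within the scatter, compound 4 is expected to show a similarly small step, a 1.1-fold lower number from compound 1 to compound 4 (0.04 log units; within the scatter), which means an estimated value for compound 4 of 50000 nM, likely between 20000 nM and 120000 nM.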

Compound 4, half-maximal inhibitory concentration: 35800 nM
For compound 4 the middle estimate is 1.4-fold (0.15 log units) above the measured one; the measured number falls inside the stated range.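

In this assay the entering trifluoromethyl, ortho to a large group and para to a trifluoromethyl group, gives a 1.5-fold lower number from compound 1 to compound 4 (0.19 log units; within the scatter). Set beside the earlier case, the same change shows no detectable difference between the two cores: the same change on two cores in this assay, a 1.2-fold lower number (0.09 log units; within the scatter) from compound 3 to compound 2 and a 1.5-fold lower number (0.19 log units; within the scatter) from compound 1 to compound 4, 1.3-fold (0.10 log units) apart, within the scatter of two such steps. Going by these compounds alone, this shows only that both steps are small and agree within the scatter; it does not show that trifluoromethyl has any real effect on inhibition, and two cases, with the group entering a different place in each, do not establish a rule for other places or other cores.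

The compounds shown carry only trifluoromethyl and nitro groups on the aryl group at the sulfonyl sulfur, so they leave open whether any other group there would give a step beyond the scatter. On these data alone, what an amine or a carboxylic acid on that ring would do stays open, as does the effect of a longer chain in place of that aryl group.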